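Three inactive spirocyclic triazoles and a diethylphenyl analogue

The compounds below may be only part of what the source reports. "The series", "measured", "known", "first", "only" and "open" are said of these compounds alone.

The series shares one spirocyclic core carrying a triazole whose aromatic nitrogen bears a varied aryl group. Compound 1 `N#CC1=C(N)Oc2c(N)cc3nc4ccccc4nc3c2C12C(=O)N(Cc1cnnn1-c1ccc(Cl)cc1)c1ccccc12` carries a 4-chlorophenyl there. In a functional assay on HepG2 cells (Homo sapiens) for antiproliferative activity, read by MTT assay, with a stated time of 48 h (on this read-out lower numbers stand for stronger inhibition and higher numbers for weaker inhibition), compound 1 gives only a limit, > 50000 nM. Compound 2 `Cc1ccc(-n2nncc2CN2C(=O)C3(C(C#N)=C(N)Oc4c(N)cc5nc6ccccc6nc5c43)c3ccccc32)cc1C` carries a 3,4-dimethylphenyl; in this assay compound 2 likewise gives only a limit, > 50000 nM. Compound 3 `Cc1cc(C)cc(-n2nncc2CN2C(=O)C3(C(C#N)=C(N)Oc4c(N)cc5nc6ccccc6nc5c43)c3ccccc32)c1` carries a 3,5-dimethylphenyl, and in this assay compound 3 again gives only a limit, > 50000 nM. Thus compound 3 stands where every other measured compound stands, at the limit of > 50000 nM in this assay, at which 3 of the 3 values shown sit, and none of the three can be ordered against another. The steps a step that the two limits leave unreadable from compound 1 to compound 2, a step that the two limits leave unreadable from compound 1 to compound 3 and a step that the two limits leave unreadable from compound 2 to compound 3 are therefore all unreadable.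

Compound 4 `CCc1cccc(CC)c1-n1nncc1CN1C(=O)C2(C(C#N)=C(N)Oc3c(N)cc4nc5ccccc5nc4c32)c2ccccc21` differs from compound 3 by 2,6-diethylphenyl in place of 3,5-dimethylphenyl on an aromatic nitrogen. Going by the values given here, the only steps that bear on this change, those among compounds 1, 2 and 3, are all unreadable, so no direction or size can be drawn from them; all they show is that three different aryl groups on this nitrogen leave the activity beyond the measurable range. Compound 4 is therefore expected to remain at the limit as well, with an estimated step that the limit leaves unreadable from compound 3 to compound 4 that is nominal only. The estimate for compound 4 is 80000 nM, within a range from 30000 nM to 300000 nM.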

Compound 4, half-maximal inhibitory concentration: 16500 nM
Compound 4: middle estimate off by 4.8-fold (0.69 log units), on the high side, and the stated range ends above it.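

Among the aryl groups shown on this aromatic nitrogen, only 2,6-diethylphenyl brings the activity within the measurable range of this assay, giving an at least 3.0-fold lower number from compound 3 to compound 4 (0.48 log units; beyond the scatter), an at least 3.0-fold lower number from compound 2 to compound 4 (0.48 log units; beyond the scatter) and an at least 3.0-fold lower number from compound 1 to compound 4 (0.48 log units; beyond the scatter). The entering and leaving groups each contain one six-membered aromatic ring of carbon only and have no hydrogen-bond donors or acceptors, so this aryl position can change the read-out without either feature being added. The steps among compound 1, compound 2 and compound 3 still cannot be read, and those three compounds remain at the assay limit: the limit of > 50000 nM in this assay, at which 3 of the 4 values shown sit.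

Compound 4 differs from compound 3 in both the length of its alkyl groups and their positions on the phenyl ring, so the compounds shown cannot separate these two changes. On these data alone, it remains open how a 2,6-dimethylphenyl or a 3,5-diethylphenyl group would read here, and whether a longer chain such as propyl or an amine on the phenyl ring would carry the activity further.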